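Adding a Methyl to the Pendant Phenyl of Compound 3

The compounds below may be only part of what the source reports. "The series", "measured", "known", "first", "only" and "open" are said of these compounds alone.

The three measured compounds share one core and differ only in the aryl bound through the oxygen-linked methylene. In a functional assay on MCF7 cells (Homo sapiens) for antiproliferative activity, read by MTT assay, with a stated time of 48 h, in the presence of a further agent that is not named here (a lower number here means a stronger inhibitor of growth, a higher number a weaker inhibitor of growth), compound 1 `O=C(NOCc1ccccc1F)c1cn(-c2ccccc2)nc1-c1ccccc1` gives 16100 nM, compound 2 `O=C(NOCc1ccccc1Cl)c1cn(-c2ccccc2)nc1-c1ccccc1` gives 7410 nM, and compound 3 `O=C(NOCc1ccc(Cl)cc1Cl)c1cn(-c2ccccc2)nc1-c1ccccc1` gives 9660 nM. Compound 3 thus stands second highest of the three; its nearest neighbour is compound 2, with a 1.3-fold higher number from compound 2 to compound 3 (0.12 log units; within the scatter), its furthest is compound 1, with a 1.7-fold lower number from compound 1 to compound 3 (0.22 log units; within the scatter). Within the data shown here, the one step beyond the scatter is a 2.2-fold lower number from compound 1 to compound 2 (0.34 log units; beyond the scatter).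

Compound 4 `Cc1ccc(-c2nn(-c3ccccc3)cc2C(=O)NOCc2ccc(Cl)cc2Cl)cc1` changes a different part of the molecule: methyl in place of hydrogen on an aromatic carbon, para to a large group. Among the measured compounds shown here, none of the measured steps touches this phenyl, so no step in this assay speaks directly to the change. Given that, the number for compound 4 is expected to stay close to that of compound 3, with a 1.1-fold lower number from compound 3 to compound 4 (0.03 log units; within the scatter) and no step beyond the scatter. The estimate for compound 4 in this assay is 9000 nM, within the range 3500 nM to 23000 nM.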

Compound 4, concentration for 50% growth inhibition: 2310 nM
Compound 4: the middle estimate sits 3.9-fold (0.59 log units) above what was measured, outside the stated range (below it).
By their numbers in this assay, from the lowest: compound 4; then compounds 2, 3 and 1 (each within the scatter of the next, the first and the last beyond it).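

The phenyl that stayed unchanged across compounds 1, 2 and 3 proves to be responsive. In this assay, among these compounds, going from phenyl to 4-methylphenyl gives a 4.2-fold lower number from compound 3 to compound 4 (0.62 log units; beyond the scatter) and so exceeds the only earlier step beyond the scatter, which is a 2.2-fold lower number from compound 1 to compound 2 (0.34 log units; beyond the scatter) on the other aryl. A single added carbon at this position therefore moves the number further than any of the halogen changes shown, although no available evidence accounts for this.

The compounds shown leave open whether a longer chain such as ethyl, or a methoxy, chloro or amino group, at the same place would carry the change further or reverse it. They also leave open whether the methyl acts in the same way alongside the 2-chlorobenzyl or 2-fluorobenzyl groups of compound 2 and compound 1.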